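This account rests on a few compounds, and the source may have more. Where it says the series, first, only, none or still open, it means among the compounds named here.

Compounds measured so far:
Compound 1 `Cc1ccnc(NC[C@@H]2CC3(CC3)CN2C(=O)c2nc(C)sc2-c2ccccc2)n1` gives 7.
Compound 2 `Cc1ccc(-c2nccs2)c(C(=O)N2CC3(CC3)C[C@H]2CNc2ccc(C(F)(F)F)cn2)n1` gives 8.

Both compounds were tested in a functional assay on HEK293 cells for antagonist activity at Orexin receptor type 2 (Homo sapiens), read by FLIPR and calcium flux; a lower number here means a less potent compound, a higher number a more potent compound, by a factor of ten per unit of this negative logarithm. Compound 2 stands highest of the two numbers; its nearest neighbour, compound 1, lies lower, and that gap is beyond the usual scatter of the measurement. The two structures differ in more than one place, so nothing is said here about which part of compound 2 carries the gain; only the two values themselves are shown.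

Compound 3 `Cc1ccc(-c2ncccn2)c(C(=O)N2CC3(CC3)C[C@H]2CNc2ccc(C(F)(F)F)cn2)n1` has not yet been measured. It keeps the core of compound 2 and differs from it in one place: pyrimidin-2-yl in place of 1,3-thiazol-2-yl on an aromatic carbon. Within the data shown here, no step between two measured compounds of this kind is available, so the size of the expected step rests on the change alone. The account expects a small step, if any, from compound 2 to compound 3, most likely downward, and within or close to the scatter: a number 0.20 log units lower from compound 2 to compound 3 (within the scatter). Compound 3 is therefore estimated at 7.8 in this assay, with a range from 7.2 to 8.4.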

Compound 3, negative logarithm of the antagonist equilibrium constant: 7.5
Estimate against measurement, compound 3: 0.30 log units above; low and high end bracket the measured number.
By their numbers in this assay, from the lowest: compound 1; then compound 3; then compound 2.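

In this assay, the ring on an aromatic carbon of the six-membered aromatic ring with 1 nitrogen, ortho to a large group, is shown not to be freely exchangeable: pyrimidin-2-yl in place of 1,3-thiazol-2-yl gives a number 0.50 log units lower from compound 2 to compound 3 (beyond the scatter), a modest step and the first in this set that can be read for a change in one place. The two groups match in the counts of hydrogen-bond donors and acceptors and carry no net charge, yet the step lies beyond the scatter, so those counts alone do not settle the value at this position. No measurement given here accounts for the loss, and the reason for it remains unknown.

Since the ring size and the hetero atoms change together in this single step, the compounds shown leave open which of the two goes with the lower value. They also leave open how this position would respond to a pyridine or an oxazole ring, either of which would begin to separate those two changes.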